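Aryl for Ethyl on the Ring Nitrogen: Compound 4

The compounds below may be only part of what the source reports. "The series", "measured", "known", "first", "only" and "open" are said of these compounds alone.

Measured compounds:
compound 1 `COc1ccc(C)cc1N1C(=O)CSC1c1cccc(C(=O)NCCCCc2ccccc2)c1` — 42%
compound 2 `COc1ccc(OC)c(N2C(=O)CSC2c2cccc(C(=O)NCCCCc3ccccc3)c2)c1` — 5%
compound 3 `CCN1C(=O)CSC1c1cccc(C(=O)NCCCCc2ccccc2)c1` — 6%

The three compounds share one core and differ only in the group on the amide-type nitrogen of the five-membered ring. In a functional assay on HOS cells (Homo sapiens) for inhibition, read by CCK-8 assay, with a stated time of 72 h, tested at 1 uM (on this read-out higher numbers stand for more inhibition at the one concentration tested (going by the name of the read-out) and lower numbers for less inhibition), compound 1 gives 42%, compound 2 gives 5%, and compound 3 gives 6%. Compound 3 thus stands second highest of the three: it lies within the scatter of compound 2, as a number 1 percentage points higher from compound 2 to compound 3 (within the scatter) shows, while a number 36 percentage points lower from compound 1 to compound 3 (beyond the scatter) is a large drop.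

Compound 4 `COc1cccc(OC)c1N1C(=O)CSC1c1cccc(C(=O)NCCCCc2ccccc2)c1` is not yet measured. It differs from compound 3 in one place:
2,6-dimethoxyphenyl in place of ethyl on an amide-type nitrogen in a ring
Going by the values given here, two measured steps bear on the reverse of this change, an aryl group for ethyl on that nitrogen. a number 36 percentage points lower from compound 1 to compound 3 (beyond the scatter) was large, whereas a number 1 percentage points higher from compound 2 to compound 3 (within the scatter) lay within the scatter. Among the compounds with values here, the entering 2,6-dimethoxyphenyl carries two methoxy groups, as does the aryl group of compound 2, though it is a different group, and no step with it is measured. Compound 4 is therefore expected to show a modest gain, a number 9 percentage points higher from compound 3 to compound 4 (within the scatter), uncertain in size. The estimate for compound 4 is 15%, between 0% and 45%.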

Compound 4, a percentage reported as inhibition, at one concentration (the size of the read-out at that concentration, not a potency): 80%
Compound 4: the middle estimate sits 65 percentage points below what was measured, outside the stated range (above it).
By their numbers in this assay, from the lowest: compounds 2 and 3 (each within the scatter of the next); then compound 1; then compound 4.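

Going by these compounds alone, with the 2,6-dimethoxyphenyl group on the amide-type nitrogen, this assay shows that this position can carry far more inhibition than the earlier compounds revealed: the result is a number 74 percentage points higher from compound 3 to compound 4 (beyond the scatter) and also a number 38 percentage points higher from compound 1 to compound 4 (beyond the scatter), which places compound 4 above all three others. The placing of the two methoxy groups on the aryl ring counts heavily at this position, since exchanging 2,5-dimethoxyphenyl for 2,6-dimethoxyphenyl gives a number 75 percentage points higher from compound 2 to compound 4 (beyond the scatter) and so the presence of two methoxy groups does not by itself decide the outcome. No measurement at hand accounts for the size of these steps.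

The compounds shown leave open whether 2,6-dimethylphenyl or 2,6-dichlorophenyl would match the 2,6-dimethoxyphenyl group on this nitrogen. They also leave open how far the result holds with a shorter chain in place of the 4-phenylbutyl chain on the other amide.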